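The source may report more compounds than this note shows. Statements on the series, on what has been measured and on what is new or still open speak of the compounds shown alone.

Compound 1, with the structure `C=C1CC[C@@H]2[C@](C)(COC(C)=O)[C@H](OC(C)=O)CC[C@@]2(C)[C@H]1CC(Nc1ccc(S(=O)(=O)Nc2ccc(Cl)nn2)cc1)C1=CCOC1=O`, and compound 2, with the structure `C=C1CC[C@@H]2[C@](C)(COC(C)=O)[C@H](OC(C)=O)CC[C@@]2(C)[C@H]1CC(Nc1ccc(S(=O)(=O)Nc2ncccn2)cc1)C1=CCOC1=O`, share one core and differ only in the ring attached to a sulfonamide nitrogen. In a functional assay on BT-549 cells (Homo sapiens) for inhibition, read by sulforhodamine B assay, with a stated time of 48 h (on this read-out higher numbers stand for weaker inhibition of growth and lower numbers for stronger inhibition of growth), compound 1 gives 1580 nM, and compound 2 gives 1640 nM. For the measured compounds named here, the only step between measured compounds is a 1.0-fold higher number from compound 1 to compound 2 (0.02 log units; within the scatter), so the two numbers cannot be told apart, and compound 1 stands level with its single neighbour rather than apart from it.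

Compound 3, with the structure `C=C1CC[C@@H]2[C@](C)(COC(C)=O)[C@H](OC(C)=O)CC[C@@]2(C)[C@H]1CC(Nc1ccc(S(=O)(=O)Nc2nccs2)cc1)C1=CCOC1=O`, keeps the same core and changes the same site: 1,3-thiazol-2-yl in place of 6-chloropyridazin-3-yl on a sulfonamide nitrogen. Going by the values given here, the one step that bears on this, from compound 1 to compound 2, swapped one six-membered aromatic ring for another at this nitrogen and stayed within the scatter. The move to a five-membered ring is not covered by any measured pair, so the expectation rests on that single flat step. The expected step in this assay is therefore a 1.1-fold higher number from compound 1 to compound 3 (0.03 log units; within the scatter), no change beyond the scatter. Compound 3 is estimated at 1700 nM, with a range from 800 nM to 3600 nM.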

Compound 3, concentration for 50% growth inhibition: 2430 nM
The estimate for compound 3 lay 1.4-fold (0.16 log units) below the measured number; low and high end bracket the measured number.
By their numbers in this assay, from the lowest: compounds 1, 2 and 3 (each within the scatter of the next).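

In this assay, this place on a sulfonamide nitrogen now has a five-membered aromatic ring to set against the two six-membered ones: the change gives a 1.5-fold higher number from compound 1 to compound 3 (0.19 log units; within the scatter), and the comparison with the other six-membered ring gives a 1.5-fold higher number from compound 2 to compound 3 (0.17 log units; within the scatter). The earlier pair covered only six-membered rings, whereas these steps show that 1,3-thiazol-2-yl, with its ring sulfur and no chlorine, can stand here without a difference that this measurement can resolve. Nothing is available to explain these numbers or to say what lies behind the small steps.

All three compounds carry an aromatic ring with hetero atoms on this nitrogen, so the compounds shown leave open how a non-aromatic group such as a methyl or an acetyl group would read here. As far as these compounds go, it also remains open whether a substituent on the ring, for instance an amine or a carboxylic acid, could move the number beyond the scatter.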